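Methylation of a phenolic hydroxyl in a flavanonol series

A few compounds are considered here, and "the series" means these few. Any claim that something is new, unique, unknown or untested is made for them only; others in the source may bear on it.

Measured compounds:
compound 1, `COc1ccc([C@@H]2Oc3cc(OC)c(O)c(OC)c3C(=O)[C@@H]2O)cc1OC` — 22%
compound 2, `COc1cc2c(c(OC)c1OC)C(=O)[C@H](O)[C@@H](c1ccc(O)cc1)O2` — 17.1%

In a functional assay on PC-12 cells (Rattus norvegicus) for cytotoxicity, read by MTT assay, with stated times of 2 h and 4 h, tested at 32 ug/mL (a lower number here means a weaker effect, a higher number a stronger effect of the compound at the concentration tested), compound 1 gives 22%, the higher of the two numbers recorded. Compound 2 in this assay gives 17.1%, and the gap between the two lies within the usual scatter of such measurements, so neither can be called the stronger of the pair. Both values sit at the low end of the read-out.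

Compound 3, `COc1ccc([C@@H]2Oc3cc(OC)c(OC)c(OC)c3C(=O)[C@@H]2O)cc1OC`, has not yet been measured. It differs from compound 1 in one place: methyl in place of hydrogen on an oxygen on an aromatic ring. Within the data shown here, no step between two measured compounds isolates this change, so there is nothing to calibrate it against. Given the low values of both measured compounds, the step from compound 1 to compound 3 in this assay is expected to be small, in either direction, and not beyond the scatter, as a number 2 percentage points lower from compound 1 to compound 3 (within the scatter) expresses. Compound 3 is therefore estimated to give 20%, within a range of 8% to 34%.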

Compound 3, a percentage reported as activity, at one concentration (the size of the read-out at that concentration, not a potency): 2.4%
Compound 3: middle estimate off by 17.6 percentage points, on the high side; the measured number lies below the stated range.
By their numbers in this assay, from the lowest: compound 3; then compounds 2 and 1 (each within the scatter of the next).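

Hydroxy to methoxy, on an oxygen on an aromatic ring, comes with a number 19.6 percentage points lower from compound 1 to compound 3 (beyond the scatter) in this assay, the first step in the series that can be tied to one place. The earlier pair could not show this, since compound 1 and compound 2 differ in more than one place and their values lie within the scatter of each other. The position is therefore not indifferent to this change: a single methyl on that oxygen goes with a lower read-out at the concentration tested. Nothing available here explains the drop.

As far as these compounds go, whether a longer chain such as ethyl, or an acetyl group, on the same oxygen would go the same way remains open. From the compounds shown here alone, it is also open whether methyl on the hydroxy of compound 2 would bring a step of similar size.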